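The source may report more compounds than this note shows. Statements on the series, on what has been measured and on what is new or still open speak of the compounds shown alone.

Two compounds of this series have a number for acid dissociation. Compound 1 `Brc1ccc(N(CC2CC2)C2=NCCN2)c(Br)c1` gives 11.2 in a physicochemical assay for acid dissociation. Compound 2 `C/C=C/CN(C1=NCCN1)c1c(Br)cccc1Br` gives 11 in this assay; this is the lower of the two numbers, and the gap to compound 1 lies within the scatter, so the two compounds cannot be told apart on this read-out. The shared core thus sits at a fairly constant level across these two substituents on the nitrogen of the aromatic ring.

Compound 3 `Brc1cccc(Br)c1N(Cc1cccs1)C1=NCCN1` is not yet measured in this assay. It differs from compound 2 in one place: thiophen-2-yl in place of prop-1-en-1-yl on a saturated chain carbon bound to a nitrogen on an aromatic ring. Among the measured compounds shown here, no step between two measured compounds is given that would show how a change of this kind moves the number. On the two values in hand, a small step is expected in this assay for compound 3, toward a slightly lower number or none beyond the scatter, so that the estimated step of a number 0.30 log units lower from compound 2 to compound 3 (within the scatter) stays close to the spread already seen. Compound 3 is therefore expected to give about 10.7, estimated between 10.2 and 11.2.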

Compound 3, acid dissociation constant: 10.5
For compound 3 the middle estimate is 0.20 log units above the measured one; low and high end bracket the measured number.
By their numbers in this assay, from the lowest: compound 3; then compounds 2 and 1 (each within the scatter of the next).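

In this assay, thiophen-2-yl in place of prop-1-en-1-yl on a saturated chain carbon bound to a nitrogen on an aromatic ring gives a number 0.50 log units lower from compound 2 to compound 3 (beyond the scatter) and so shows that this position can move the number, though only modestly. Among the compounds shown here, this is the only step so far between two compounds that differ in one place, so it gives a size and a direction for this single exchange and no trend for the position. Nothing on hand bears on what lies behind the step.

From the compounds shown here alone, whether the step belongs to thiophen-2-yl itself or would follow from any five-membered or six-membered aromatic ring on this chain carbon stays open, and furan-2-yl or phenyl at the same place would separate those two readings. Going by these compounds, how far the number can travel at this position is also open, and an amine, a carboxylic acid or a longer saturated chain in place of thiophen-2-yl would mark out that range on the same shared core.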